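Swapping the lactam substituent on the shared core

The compounds below may be only part of what the source reports. "The series", "measured", "known", "first", "only" and "open" are said of these compounds alone.

Among the measured compounds shown here, compound 1 `O=C1OC(c2ccccc2)CN1c1cnn2c1CN(C(=O)Nc1cc(F)c(F)c(F)c1)C(C1CC1)C2` is the only member of this small set with a numerical read-out in a toxicity assay on HepG2 2.2.15 cells (Homo sapiens) for cytotoxicity, read by CellTiter-Glo (a lower number here means that less compound is tolerated, a higher number that more compound is tolerated), where compound 1 gives 7410 nM. Compound 2 `C[C@H]1Cn2ncc(N3CC(c4ccccc4)CC3=O)c2CN1CC(=O)Nc1cc(F)c(F)c(F)c1` reaches only a limit in this assay, and for compound 2 the read-out is > 2000 nM. Compound 3 `C[C@H]1Cn2ncc(N3CC(c4ccccc4)CC3=O)c2CN1C(=O)NCc1cc(F)c(F)c(F)c1` likewise stops at a limit in this assay, with compound 3 giving > 2000 nM. For the measured compounds named here, the picture is therefore framed by the limit of > 2000 nM in this assay, at which 2 of the 3 values shown sit, so compound 1 stands as the single measured number while the other two offer only a limit.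

Going by the values given here, no two measured compounds differ in a single place, so no measured step is available to calibrate a structural change. Compound 4 `O=C1CC(c2ncccn2)CN1c1cnn2c1CN(C(=O)Nc1cc(F)c(F)c(F)c1)C(C1CC1)C2` has not been measured; it differs from compound 1 in one place, as follows: 2-oxo-4-(pyrimidin-2-yl)pyrrolidin-1-yl in place of 2-oxo-5-phenyl-1,3-oxazolidin-3-yl on an aromatic carbon. The leaving and entering groups carry the same count of heavy atoms, and the entering group brings one more hydrogen-bond acceptor.

Among the compounds with values here, with no measured step to lean on, the change from compound 1 to compound 4 is expected to stay within the usual scatter of this assay, with no clear direction. Compound 4 is estimated to give 8000 nM in this assay, with a range from 3000 nM to 25000 nM. The estimated step of a 1.1-fold higher number from compound 1 to compound 4 (0.03 log units; within the scatter) is expected to be small.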

Compound 4, half-maximal cytotoxic concentration: > 200000 nM
Compound 4: a limit, no number (the forecaster's own chance of this, stated with the estimate: 40%); middle value at least 25-fold (1.39 log units) away from the limit.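

On an aromatic carbon of the five-membered aromatic ring with 2 nitrogen, the set now has its first measured step: 2-oxo-4-(pyrimidin-2-yl)pyrrolidin-1-yl in place of 2-oxo-5-phenyl-1,3-oxazolidin-3-yl gives an at least 26-fold higher number from compound 1 to compound 4 (1.43 log units; beyond the scatter) in this assay. This position is therefore not indifferent in this assay, since an exchange between two groups with the same count of heavy atoms moves the read-out beyond the scatter, towards more compound being tolerated. Compound 4 gives > 200000 nM, which is a limit and not a number, so the full size of the step stays unknown, and no other compound shown sits at this limit: the limit of > 200000 nM in this assay, at which 1 of the 4 values shown sits.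

The exchange alters the five-membered ring and the aromatic ring at once, so the compounds shown cannot say which of the two carries the step, and a 2-oxo-5-(pyrimidin-2-yl)-1,3-oxazolidin-3-yl group on the core of compound 1 would separate them. Nor do they show whether a pyridin-2-yl ring on the same lactam would give a measurable number rather than a limit.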